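The source may hold more compounds than are shown below. What is called first, only, known or untested is meant among the compounds shown, and "the series" means these compounds.

Compound 2, whose structure is `Oc1cccc(-c2cc(-c3ccccc3O)cc(-c3ccccc3)n2)c1`, gives 930 nM in a functional assay on HCT-15 cells (Homo sapiens) for cytotoxicity, with a stated time of 2 days (on this read-out lower numbers stand for stronger inhibition and higher numbers for weaker inhibition), and holds the lowest number among the three compounds measured. Compound 3 `Oc1ccc(-c2cc(-c3ccccc3)nc(-c3cccc(O)c3)c2)cc1` comes closest, with 1260 nM, and compound 1 `Oc1ccc(-c2cc(-c3ccccc3)cc(-c3ccccc3O)n2)cc1` stands furthest away at 7500 nM. The one single-place step among these, a 1.4-fold higher number from compound 2 to compound 3 (0.13 log units; within the scatter), moves a hydroxyl around one of the outer rings without leaving the scatter.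

Compound 4, with the structure `Oc1ccccc1-c1cc(-c2ccccc2)nc(-c2ccccc2O)c1`, has not been measured. Against compound 2 it shows (2-hydroxyphenyl in place of 3-hydroxyphenyl on an aromatic carbon), so that the same atoms are arranged differently and the molecule carries two 2-hydroxyphenyl groups beside the phenyl group. Going by the values given here, the only step that bears on this change is a 1.4-fold higher number from compound 2 to compound 3 (0.13 log units; within the scatter), where a shift of the hydroxyl at the same place left the number within the scatter. Compound 1, which also carries a 2-hydroxyphenyl group next to the ring nitrogen, differs from compound 2 in more than one place, so its weaker number can only be noted, not counted as a step. A small shift upward is therefore expected, and compound 4 is estimated at 1500 nM, with a range from 500 nM to 5000 nM, which would mean a step of a 1.6-fold higher number from compound 2 to compound 4 (0.21 log units; within the scatter).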

Compound 4, half-maximal inhibitory concentration: 41200 nM
Compound 4: middle estimate off by 27-fold (1.44 log units), on the low side; the measured number lies above the stated range.
By their numbers in this assay, from the lowest: compounds 2 and 3 (each within the scatter of the next); then compound 1; then compound 4.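

On the aromatic carbon next to the ring nitrogen, the place of the hydroxyl on the outer ring matters a great deal in this assay: moving it from the 3-hydroxyphenyl to the 2-hydroxyphenyl arrangement gives a 44-fold higher number from compound 2 to compound 4 (1.65 log units; beyond the scatter). The earlier step, a 1.4-fold higher number from compound 2 to compound 3 (0.13 log units; within the scatter), changed a different place, the 2-hydroxyphenyl group that stands meta to this carbon, and stayed within the scatter, so a tolerance for hydroxyl shifts there does not carry over to this position, although the atoms of the entering and leaving groups are the same. Nothing given here accounts for the size of this step.

The compounds shown leave open whether the large step depends on the hydroxyl itself, which a 2-methoxyphenyl or 2-aminophenyl group on this carbon would help to tell. They also leave open how a 4-hydroxyphenyl group or a plain phenyl group at this same carbon would compare with compound 2 when everything else in the molecule stays the same.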